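The compounds below may be only part of what the source reports. "The series", "measured", "known", "first", "only" and "open" are said of these compounds alone.

Three compounds share the same pair of linked double bonds around a carbonyl, with a triazole tether to a coumarin-like fragment, and differ in the ring at one end of that chain or in the length of the tether. Compound 1 `COc1cc(/C=C/C(=O)/C=C/c2ccco2)ccc1OCc1cn(CCCCOc2cc(=O)oc3ccccc23)nn1` and compound 3 `COc1cc(/C=C/C(=O)/C=C/c2ccco2)ccc1OCc1cn(CCOc2cc(=O)oc3ccccc23)nn1` carry a furan-2-yl ring at that position; how their two cores differ is not broken down here. Compound 2 `COc1ccccc1/C=C/C(=O)/C=C/c1ccc(OCc2cn(CCCCOc3cc(=O)oc4ccccc34)nn2)c(OC)c1` is compound 1 with 2-methoxyphenyl in place of furan-2-yl on a double-bonded chain carbon bound to a double-bonded chain carbon.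

In a functional assay on HCT-116 cells (Homo sapiens) for inhibition, read by sulforhodamine B assay, with a stated time of 48 h, tested at 50 uM (a higher number here means more inhibition of growth at the concentration tested, a lower number less inhibition of growth), compound 1 gives 47%, and compound 2 gives 43%. The change from the furan ring to the methoxyphenyl ring thus made a step of a number 4 percentage points lower from compound 1 to compound 2 (within the scatter), so the two values cannot be told apart. Compound 3 stands highest of the three in this assay with 72%, beyond the scatter from both compound 1 and compound 2.

Compound 4 `COc1ccccc1/C=C/C(=O)/C=C/c1ccc(OCc2cn(CCOc3cc(=O)oc4ccccc34)nn2)c(OC)c1` applies the same change to compound 3: 2-methoxyphenyl in place of furan-2-yl on a double-bonded chain carbon bound to a double-bonded chain carbon. Since the place is the same in both pairs, this is the same change, seen a second time. Because the earlier instance gave a number 4 percentage points lower from compound 1 to compound 2 (within the scatter), compound 4 is expected to move only a little from compound 3, by about a number 6 percentage points lower from compound 3 to compound 4 (within the scatter). In this assay compound 4 is therefore estimated at 66%, most likely between 48% and 80%.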

Compound 4, percent growth inhibition at one concentration: 70%
For compound 4 the middle estimate is 4 percentage points below the measured one; the range from low to high includes it.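

On the second core, putting 2-methoxyphenyl in place of furan-2-yl gives a number 2 percentage points lower from compound 3 to compound 4 (within the scatter) in this assay, so here too the swap leaves no readable mark on growth inhibition. The two instances of the change agree: the same change on two cores in this assay, a number 4 percentage points lower (within the scatter) from compound 1 to compound 2 and a number 2 percentage points lower (within the scatter) from compound 3 to compound 4, 2 percentage points apart, within the scatter of two such steps

This shows that, in this series, the swap from furan-2-yl to 2-methoxyphenyl behaved the same way on both cores, on one where compound 1 gives 47% and on one where compound 3 gives 72%, so the ring at this place can be exchanged without a visible cost in this read-out. It does not show that the same would hold on any further core, since two pairs are a small sample, and a step that stays within the scatter twice says only that no effect was seen at this one concentration, not that the two rings are equivalent in every respect.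

The compounds shown leave open what a quite different group at this place, such as an amine or a carboxylic acid in place of furan-2-yl, would do to growth inhibition. They also leave open whether the two rings would still match at other concentrations or in other cell lines.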